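The source may report more compounds than this note shows. Statements on the series, on what has been measured and on what is new or still open speak of the compounds shown alone.

As far as these compounds go, the series rests on three measured compounds and one still open. Compound 1 `CC(C)(C)c1ccc(-n2nc(-c3ccc(C(F)(F)F)cc3O)nc2-c2ccccc2O)cc1` gives 81.1% in a functional assay on PC-12 cells (Rattus norvegicus) for cytotoxicity, read by MTT assay, with stated times of 2 h and 24 h, tested at 10 uM; a higher number here means a stronger effect of the compound at the concentration tested, a lower number a weaker effect. Compound 2 `Oc1cc(C(F)(F)F)ccc1-c1nc(-c2ccccc2O)n(-c2ccc(F)cc2)n1` gives 99.8%, and compound 3 `Oc1cc(C(F)(F)F)ccc1-c1nc(-c2ccccc2O)n(-c2ccc(OC(F)(F)F)cc2)n1` gives 92.5%. Compound 2 thus stands at the top of the three numbers, but only the gap to compound 1 is telling: the step of a number 18.7 percentage points higher from compound 1 to compound 2 (beyond the scatter) lies beyond the scatter, whereas the step of a number 7.3 percentage points lower from compound 2 to compound 3 (within the scatter) does not, so compound 2 and compound 3 cannot be told apart here.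

Compound 4 `Oc1cc(C(F)(F)F)ccc1-c1nc(-c2ccccc2O)n(-c2ccccc2F)n1` differs from compound 2 in one place: 2-fluorophenyl in place of 4-fluorophenyl on an aromatic nitrogen. The measured steps that touch this position are the exchange of tert-butyl for fluoro, a number 18.7 percentage points higher from compound 1 to compound 2 (beyond the scatter), the exchange of tert-butyl for trifluoromethoxy, a number 11.4 percentage points higher from compound 1 to compound 3 (beyond the scatter), and the exchange of fluoro for trifluoromethoxy, a number 7.3 percentage points lower from compound 2 to compound 3 (within the scatter). None of them moves a fluorine around the same ring; the two that are beyond the scatter both leave tert-butyl behind. With no step of this kind shown, the expectation for compound 4 is a step of a number 5.8 percentage points lower from compound 2 to compound 4 (within the scatter), that is, none beyond the scatter. Compound 4 is therefore estimated at 94%, between 80% and 105%.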

Compound 4, a percentage reported as activity, at one concentration (the size of the read-out at that concentration, not a potency): 100%
Compound 4: the middle estimate sits 6 percentage points below what was measured; low and high end bracket the measured number.
By their numbers in this assay, from the lowest: compound 1; then compounds 3, 2 and 4 (each within the scatter of the next).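

Shifting the fluorine from 4-fluorophenyl to 2-fluorophenyl on the aromatic nitrogen keeps the substituent and changes only where it sits, and in this assay the step of a number 0.2 percentage points higher from compound 2 to compound 4 (within the scatter) shows that this shift cannot be told from no change. The comparison with the trifluoromethoxy group gives a number 7.5 percentage points higher from compound 3 to compound 4 (within the scatter), while the comparison with the tert-butyl group gives a number 18.9 percentage points higher from compound 1 to compound 4 (beyond the scatter), so compound 1 alone stands apart, and compound 2, compound 3 and compound 4 form one group. Nothing available here accounts for this outcome.

The compounds shown leave open whether a phenyl ring carrying an amine or a carboxylic acid in place of the fluorine would stay with that group or fall toward compound 1. They also leave open what the trifluoromethyl group on the shared core contributes, as all four compounds keep it.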